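The source may report more compounds than this note shows. Statements on the series, on what has been measured and on what is new or still open speak of the compounds shown alone.

Going by the values given here, compound 1 `CCc1ccc(-c2ccc(NC3=CC(=O)c4ncncc4C3=O)cc2)cc1` is one of two compounds measured in a functional assay on BXPC-3 cells (Homo sapiens) for cytotoxicity, read by MTT assay, with a stated time of 72 h; on this read-out higher numbers stand for weaker inhibition and lower numbers for stronger inhibition. In this assay compound 1 gives 3100 nM, and compound 2 `Cc1ccc(-c2ccc(NC3=CC(=O)c4ncncc4C3=O)cc2F)cc1` gives 5000 nM; the two numbers lie within the usual scatter of each other, so neither stands apart. Compound 3 `O=C1C(Nc2ccc(OC(F)(F)F)cc2)=CC(=O)c2ncncc21` has not been measured. It differs from compound 1 as follows: trifluoromethoxy in place of 4-ethylphenyl on an aromatic carbon. Among the compounds with values here, with no measured step of this kind to lean on, a moderate rise in the number is expected, beyond the scatter. Compound 3 is therefore estimated at 8000 nM in this assay, with a range from 2500 nM to 25000 nM, a step of a 2.6-fold higher number from compound 1 to compound 3 (0.41 log units; beyond the scatter).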

Compound 3, half-maximal inhibitory concentration: 900 nM
Beside the measured number, compound 3's estimate is 8.9-fold (0.95 log units) above it, outside the stated range (below it).
By their numbers in this assay, from the lowest: compound 3; then compounds 1 and 2 (each within the scatter of the next).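

In this assay, the 4-ethylphenyl group of compound 1 proves dispensable at this place on the aromatic ring: trifluoromethoxy in its stead gives a 3.4-fold lower number from compound 1 to compound 3 (0.54 log units; beyond the scatter), a modest step in favour of the smaller group, which carries no ring. Nothing available bears on why the number moves. Going by these compounds, whether the gain belongs to trifluoromethoxy itself or simply to the loss of the 4-ethylphenyl ring stays open. A methoxy group or a chlorine atom at the same place on the shared core would separate the two.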